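A methyl for a nitro on the ring nitrogen

The source may report more compounds than this note shows. Statements on the series, on what has been measured and on what is new or still open speak of the compounds shown alone.

Two compounds of this series share a core and differ only in the aryl group on the amide-type nitrogen in the ring. Compound 1 `COc1ccccc1N1C(=O)/C(=C/c2ccc(OCc3ccc(C(=O)O)cc3)cc2)SC1=S` carries a 2-methoxyphenyl there and in an assay on isolated protein for inhibition of Apoptosis regulator Bcl-2 (Homo sapiens), read by fluorescence polarization (a lower number here means a stronger inhibitor, a higher number a weaker inhibitor), compound 1 gives 2000 nM. Compound 2 `O=C(O)c1ccc(COc2ccc(/C=C3\SC(=S)N(c4ccc([N+](=O)[O-])cc4)C3=O)cc2)cc1` carries a 4-nitrophenyl instead, and for compound 2 the read-out is only a limit, > 10000 nM. The step of an at least 5.0-fold higher number from compound 1 to compound 2 (0.69 log units; beyond the scatter) is therefore known only as a lower bound, since compound 2 sits at the limit of > 10000 nM in this assay, at which 1 of the 2 values shown sits. Compound 3 `Cc1cccc(N2C(=O)/C(=C/c3ccc(OCc4ccc(C(=O)O)cc4)cc3)SC2=S)c1` is the next step: 3-methylphenyl in place of 4-nitrophenyl on an amide-type nitrogen in a ring. Compound 1 shows that a substituted phenyl on this nitrogen can reach 2000 nM, so a move back toward that range is expected, though how far it goes is open. The expected step of an at least 2.5-fold lower number from compound 2 to compound 3 (0.39 log units; beyond the scatter) points to a lower number. Compound 3 is estimated at 4000 nM, within 1500 nM to 15000 nM.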

Compound 3, inhibition constant: > 10000 nM
Compound 3 ended at the assay's limit (the forecaster's own chance of this, stated with the estimate: 35%); middle value at least 2.5-fold (0.39 log units) from the limit.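

Swapping 4-nitrophenyl for 3-methylphenyl on the amide-type nitrogen gives no readable gain in this assay: compound 3 gives > 10000 nM, which is a limit of the assay and not a number. Compound 2 and compound 3 both stand at a limit, so the step between them cannot be read: the limit of > 10000 nM in this assay, at which 2 of the 3 values shown sit. What the result adds is a second comparison with the 2-methoxyphenyl of compound 1: 3-methylphenyl in its place gives an at least 5.0-fold higher number from compound 1 to compound 3 (0.69 log units; beyond the scatter), so two different aryl groups on this nitrogen now give a higher number than the 2-methoxyphenyl does.

The compounds shown leave open how far compound 2 and compound 3 lie past the limit. They also leave open what an unsubstituted phenyl, a 2-methylphenyl or a 3-methoxyphenyl would give on this nitrogen, and so whether the methoxy group or its place on the ring matters more.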